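Swapping the aryl group on the ring amine of compound 3

This account rests on a few compounds, and the source may have more. Where it says the series, first, only, none or still open, it means among the compounds named here.

Measured so far:
- compound 1 `COC(=O)C1=C(C)N=C(C)/C(=C(/O)OC)C1c1cccc(N/C(=N/CCNC2CCN(c3ccccc3C)CC2)NC#N)c1`: 4 nM
- compound 2 `COC(=O)C1=C(C)N=C(C)/C(=C(/O)OC)C1c1cccc(N/C(=N/CCNC2CCN(c3ccccc3O)CC2)NC#N)c1`: 5 nM
- compound 3 `COC(=O)C1=C(C)N=C(C)/C(=C(/O)OC)C1c1cccc(NC(=O)NCCNC2CCN(c3ccccc3[N+](=O)[O-])CC2)c1`: 2 nM

In an assay on SK-N-MC cells for inhibition of Neuropeptide Y receptor type 1 (Homo sapiens) (a lower number here means a stronger inhibitor, a higher number a weaker inhibitor), compound 3 gives the lowest of the three numbers. Its gap to compound 1 lies within the scatter, while its gap to compound 2 lies beyond it, so compound 3 can be called stronger than compound 2 but not than compound 1.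

Compound 4 `COC(=O)C1=C(C)N=C(C)/C(=C(/O)OC)C1c1cccc(NC(=O)NCCNC2CCN(c3cccc(Cl)c3)CC2)c1` differs from compound 3 in one place: 3-chlorophenyl in place of 2-nitrophenyl on an amine nitrogen in a ring. Among the compounds with values here, the only measured step that touches the same aryl group is the one within the scatter, a 1.3-fold higher number from compound 1 to compound 2 (0.10 log units; within the scatter), where a hydroxy replaced a methyl on that ring. Within the data shown here, compounds 1 and 3 differ in two places at once, so no single step links them; compound 1 gives 4 nM and compound 3 gives 2 nM, and these two numbers simply lie close together. A change of substituent on this ring has thus left the number roughly where it was. The new change removes a group with two acceptors and adds chlorine at another position, so a small loss is estimated as the likelier outcome, but not a large one.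

For compound 4, then, a step of a 2.0-fold higher number from compound 3 to compound 4 (0.30 log units; within the scatter) is expected, giving an estimate of 4 nM with a range from 1.5 nM to 12 nM.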

Compound 4, half-maximal inhibitory concentration: 8 nM
Estimate against measurement, compound 4: 2.0-fold (0.30 log units) below; the range from low to high includes it.
By their numbers in this assay, from the lowest: compounds 3, 1, 2 and 4 (each within the scatter of the next, the first and the last beyond it).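

In this assay, the step of a 4.0-fold higher number from compound 3 to compound 4 (0.60 log units; beyond the scatter) is beyond the scatter, while the earlier step on this aryl group, a 1.3-fold higher number from compound 1 to compound 2 (0.10 log units; within the scatter), stayed within it, so the compounds now show that the number can respond to a change of aryl group on this amine nitrogen in a ring, though only modestly. This change is not a simple exchange of one substituent for another: 2-nitrophenyl, with its 2 hydrogen-bond acceptors, leaves, and 3-chlorophenyl, with none, enters, so both the substituent and its place on the aromatic ring differ in a single step. Nothing available here bears on why the number rose.

On these data alone, whether the step follows from losing the nitro group, from gaining the chlorine or from the new place of the substituent stays open, as the two compounds change all of these together. An unsubstituted phenyl ring on the same nitrogen, or an aromatic ring carrying an amine or a carboxylic acid, would show how far this position tolerates other groups and would give the step a plain reference point.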